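Shortening the Propyl Amide to an Ethyl Amide

A few compounds are considered here, and "the series" means these few. Any claim that something is new, unique, unknown or untested is made for them only; others in the source may bear on it.

In a functional assay on K562 cells (Homo sapiens) for antiproliferative activity, read by CCK-8 assay, with a stated time of 72 h (on this read-out lower numbers stand for stronger inhibition of growth and higher numbers for weaker inhibition of growth), compound 1 `CC[C@@H]1C(=O)N(C)c2cnc(-n3ccc4cc(C(N)=O)ccc43)nc2N1C1CCCC1` gives 1850 nM and compound 2 `CCCNC(=O)c1ccc2c(ccn2-c2ncc3c(n2)N(C2CCCC2)[C@H](CC)C(=O)N3C)c1` gives 395 nM, the lower of the two numbers. Compound 3 `CCNC(=O)c1ccc2c(ccn2-c2ncc3c(n2)N(C2CCCC2)[C@H](CC)C(=O)N3C)c1` differs from compound 2 by hydrogen in place of methyl on a saturated chain carbon, two bonds along the chain from an amide-type nitrogen, with hydrogen in place of methyl on a saturated chain carbon. Within the data shown here, the one measured step bearing on this is a 4.7-fold lower number from compound 1 to compound 2 (0.67 log units; beyond the scatter), where propyl took the place of hydrogen on an amide-type nitrogen. Shortening that propyl should give back a small share of this gain. The expected change is a 1.5-fold higher number from compound 2 to compound 3 (0.18 log units; within the scatter). For compound 3 the estimated value is 600 nM, within a range of 280 nM to 1250 nM.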

Compound 3, concentration for 50% growth inhibition: 428 nM
For compound 3 the middle estimate is 1.4-fold (0.15 log units) above the measured one; measured number inside the range.
By their numbers in this assay, from the lowest: compounds 2 and 3 (each within the scatter of the next); then compound 1.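

In this assay, the step from propyl to ethyl on the amide-type nitrogen shows a 1.1-fold higher number from compound 2 to compound 3 (0.03 log units; within the scatter) and so separates the two chains by nothing that can be read. Ethyl keeps the gain over hydrogen on that nitrogen, with a 4.3-fold lower number from compound 1 to compound 3 (0.64 log units; beyond the scatter) as the step, so the methyl that leaves is not needed for it in this pair. Nothing available here explains this result.

From the compounds shown here alone, it remains open whether methyl on that nitrogen would keep the gain. A longer chain such as butyl, or a carboxylic acid at the chain end, is also untested in the compounds shown.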